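Bromo in Place of Methyl on the Shared Core

The source may hold more compounds than are shown below. What is called first, only, known or untested is meant among the compounds shown, and "the series" means these compounds.

The three measured compounds share one core and differ only in the group on one aromatic carbon of the five-membered aromatic ring with 2 nitrogen. Compound 1 `O=C(O)c1ccn(Cc2cc(Br)ccc2OCc2ccccc2)n1` carries hydrogen there; in an assay on CHO-K1 cells for displacement of a labelled ligand from prostaglandin E2 receptor EP1 subtype (Homo sapiens) (a higher number here means a weaker inhibitor, a lower number a stronger inhibitor), compound 1 gives 9.77 nM. Compound 2 `O=C(O)c1nn(Cc2cc(Br)ccc2OCc2ccccc2)cc1F` carries fluoro, and in this assay compound 2 gives 123 nM. Compound 3 `Cc1cn(Cc2cc(Br)ccc2OCc2ccccc2)nc1C(=O)O` carries methyl, and in this assay compound 3 gives 427 nM, the highest of the three numbers and beyond the scatter from each of the others. The step of a 13-fold higher number from compound 1 to compound 2 (1.10 log units; beyond the scatter) and the step of a 44-fold higher number from compound 1 to compound 3 (1.64 log units; beyond the scatter) are both large; the step of a 3.5-fold higher number from compound 2 to compound 3 (0.54 log units; beyond the scatter) is modest.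

Compound 4 `O=C(O)c1nn(Cc2cc(Br)ccc2OCc2ccccc2)cc1Br` is not yet measured. Its change from compound 3 is bromo in place of methyl on an aromatic carbon. For the measured compounds named here, the steps that bear on it are the two replacements of hydrogen, both large increases, and the modest further increase from fluoro to methyl. Bromo is a third substituent at the same place, so no step beyond the scatter is expected, with a 1.4-fold lower number from compound 3 to compound 4 (0.15 log units; within the scatter) the expected outcome. Compound 4 is estimated at 300 nM, with a range from 80 nM to 1200 nM.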

Compound 4, half-maximal inhibitory concentration: 457 nM
The estimate for compound 4 lay 1.5-fold (0.18 log units) below the measured number, and the stated range covers the measured number.
By their numbers in this assay, from the lowest: compound 1; then compound 2; then compounds 3 and 4 (each within the scatter of the next).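

In this assay, bromo in place of methyl on this aromatic carbon, next to the ring atom that bears a carboxy group, gives a 1.1-fold higher number from compound 3 to compound 4 (0.03 log units; within the scatter) and so leaves the two groups indistinguishable at this position in this read-out. Against the other two compounds, bromo in place of fluoro gives a 3.7-fold higher number from compound 2 to compound 4 (0.57 log units; beyond the scatter) and bromo in place of hydrogen gives a 47-fold higher number from compound 1 to compound 4 (1.67 log units; beyond the scatter), so bromo joins methyl as a modest step from fluoro and a large step from hydrogen, and all three replacements of hydrogen shown here go with a higher number, with no exception among the four compounds. No accompanying data bear on the cause of these steps.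

Still open, as far as these compounds go, is whether an amine, a hydroxyl or a methoxy group on this carbon would stay close to compound 1 or fall with compounds 3 and 4. A longer chain such as ethyl, or a larger halogen such as iodo, could show whether the level shared by methyl and bromo holds for further groups at this place.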